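The compounds below may be only part of what the source reports. "The series", "measured", "known", "first", "only" and "open" are said of these compounds alone.

Measured so far:
compound 1, `O=C1CC(c2nc(-c3cccc(Cl)c3)no2)CN1c1ccc(Cl)cc1`: 140 nM
compound 2, `O=C1CC(c2nc(-c3ccc(Cl)cc3)no2)CN1c1ccc(Cl)c(Cl)c1`: 1100 nM

Both numbers come from an in vitro functional assay on HEK293-A cells for positive allosteric modulation of metabotropic glutamate receptor 5 (Homo sapiens), read by FLIPR and calcium flux; on this read-out higher numbers stand for an effect only at larger amounts of compound and lower numbers for an effect already at smaller amounts. Compound 2 has the highest of the two numbers; its nearest neighbour, compound 1, sits lower by a gap beyond the usual scatter of repeated measurements, so compound 1 acts already at smaller amounts. The two compounds differ in more than one place, so no single step can be read off between them.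

Compound 3, `O=C1CC(c2nc(-c3cccc(F)c3)no2)CN1c1ccc(Cl)c(Cl)c1`, has not yet been measured. It differs from compound 2 in one place only: 3-fluorophenyl in place of 4-chlorophenyl on an aromatic carbon. Within the data shown here, no measured pair shows what such an exchange does, so the expectation rests on compound 2 alone. The leaving and entering groups are alike in what is counted, and a step of modest size in either direction, or none beyond the scatter, would not be surprising; the estimate leans slightly toward a lower number, that is, an effect at somewhat smaller amounts. In this assay compound 3 is expected to give 600 nM, with a range from 150 nM to 2500 nM. This expectation amounts to a 1.8-fold lower number from compound 2 to compound 3 (0.26 log units; within the scatter).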

Compound 3, half-maximal effective concentration: 3200 nM
Estimate against measurement, compound 3: 5.3-fold (0.73 log units) below; measured number outside the range, above it.
By their numbers in this assay, from the lowest: compound 1; then compound 2; then compound 3.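

In this assay, putting 3-fluorophenyl in place of 4-chlorophenyl on this carbon of the five-membered aromatic ring gives a 2.9-fold higher number from compound 2 to compound 3 (0.46 log units; beyond the scatter), so with this change a larger amount of compound is needed for the effect. The two groups count alike, each with 7 heavy atoms, one six-membered aromatic ring of carbon only and no hydrogen-bond donors or acceptors, so these counts alone do not settle how this position responds, although the step is modest. The exchange alters the halogen and its location on the phenyl ring together, and no measurement at hand explains the shift.

Which of those two alterations carries the step stays open, and 4-fluorophenyl on the core of compound 2 would differ from compound 2 in the halogen alone. Among these compounds, compound 1 differs from compound 2 and from compound 3 in more than one place, so no step to it can be read, and how plain phenyl or a pyridine ring would behave on this carbon remains unknown.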